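The source may hold more compounds than are shown below. What is called first, only, known or untested is meant among the compounds shown, and "the series" means these compounds.

Of the compounds shown here, three sharing one core have been tested in an in vitro ADME assay on microsomes from liver (Homo sapiens) for pharmacokinetics, read by LC-MS; on this read-out lower numbers stand for slow clearance and higher numbers for fast clearance. Compound 1 `Cc1nc2ccc(OC(F)(F)F)cc2n1-c1ccc(C(=O)NC2CC2)s1` gives 10 mL/min/kg, and compound 2 `Cc1nc2cc(C(F)(F)F)ccc2n1-c1ccc(C(=O)NC2CC2)s1` gives 4 mL/min/kg. For compound 3 `Cc1nc2c(F)cccc2n1-c1ccc(C(=O)NC2CC2)s1`, the assay reports only a limit, < 4 mL/min/kg. That places compound 3 at the limit of < 4 mL/min/kg in this assay, at which 1 of the 3 values shown sits.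

Compound 4 `Cc1nc2c(C#N)cccc2n1-c1ccc(C(=O)NC2CC2)s1` has not yet been measured. It differs from compound 3 by having cyano in place of fluoro on an aromatic carbon. For the measured compounds named here, no measured pair in this small set differs in one place only, so there is no direct guide to what this swap will do. Going by the values given here, the only wider guide is the span of numbers seen on this core so far, set by compound 2 at 4 mL/min/kg and compound 1 at 10 mL/min/kg. Compound 4 is expected to stay within or close to that span, and a result reported only as a limit would not be a surprise. The expected step of an at least 1.2-fold higher number from compound 3 to compound 4 (0.09 log units; that floor lies within the scatter) is small, either a slight rise in clearance or nothing beyond the usual scatter. For compound 4, the estimated clearance is 5 mL/min/kg, with an expected range of 3 mL/min/kg to 9 mL/min/kg.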

Compound 4, clearance: < 4 mL/min/kg
Compound 4: a limit, no number; the forecaster's own chance of this, stated with the estimate: 40%; middle value at least 1.2-fold (0.09 log units) away from the limit.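

Compound 3 and compound 4 are both reported only as limits in this assay and so no step from one to the other can be read: the limit of < 4 mL/min/kg in this assay, at which 2 of the 4 values shown sit.

The compounds shown leave open whether cyano in place of fluoro on an aromatic carbon changes clearance at all, and in which direction.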